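The compounds below may be only part of what the source reports. "The series", "measured", "known", "first", "only" and "open" are said of these compounds alone.

Measured compounds:
compound 1 `O=C(NCCO)c1cccc(-c2cccc3cc(Cc4cccc(C(F)(F)F)c4)oc23)c1` — 34.7 nM
compound 2 `Cc1c(Cc2cccc(C(F)(F)F)c2)oc2cccc(-c3cccc(C(=O)NCCO)c3)c12` — > 10000 nM

Of the compounds shown here, two have been tested in a functional assay on CHO cells for agonist activity at G-protein coupled receptor 52 (Homo sapiens), read by AlphaScreen and cAMP accumulation, with a stated time of 30 min; a higher number here means that more compound is needed for the effect, a lower number that less compound is needed. Going by the values given here, compound 1 gives 34.7 nM, the only actual number among the two results. For compound 2 the result is a limit rather than a number: > 10000 nM, which is the limit of > 10000 nM in this assay, at which 1 of the 2 values shown sits. Among the values shown, compound 1 therefore stands alone with a measurable reading.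

Compound 3 `Cc1c(Cc2cccc(C(F)(F)F)c2)oc2c(-c3cccc(C(=O)NCCO)c3)cccc12` is not yet measured. It differs from compound 1 by a single change: methyl in place of hydrogen on an aromatic carbon. Among the compounds with values here, no measured pair shares this exact change, so the size of the step has to be guessed. A small group added at this aromatic carbon of the shared core is expected to cost some activity, though a modest loss rather than a collapse. For compound 3 the expected result in this assay is 150 nM, within a range from 30 nM to 1000 nM. The step from compound 1 to compound 3 is thus estimated at a 4.3-fold higher number from compound 1 to compound 3 (0.64 log units; beyond the scatter).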

Compound 3, half-maximal effective concentration: 81.3 nM
Compound 3: the middle estimate sits 1.8-fold (0.27 log units) above what was measured; the range from low to high includes it.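

In this assay, placing methyl in place of hydrogen on the aromatic carbon next to the ring atom that bears a 3-(trifluoromethyl)benzyl group gives a 2.3-fold higher number from compound 1 to compound 3 (0.37 log units; beyond the scatter), a modest loss. Going by these compounds alone, this is the first sign that this position accepts a small added group and that the response survives it, so the methyl alone does not abolish activity. Compound 2 carries the same methyl but has its amide-bearing phenyl ring on a different carbon of the shared core, and its result is a limit, not a number: the limit of > 10000 nM in this assay, at which 1 of the 3 values shown sits.

As far as these compounds go, whether an ethyl group, a methoxy group or an amine on this same carbon would be accepted remains open. Also open, from the compounds shown here alone, is how the amide-bearing phenyl ring at that other carbon would fare with hydrogen instead of methyl.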